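Demethylation at the Core of a Chalcone Series

A few compounds are considered here, and "the series" means these few. Any claim that something is new, unique, unknown or untested is made for them only; others in the source may bear on it.

Three chalcones sharing one core have been tested in a functional assay on HCT-116 cells (Homo sapiens), read by fluorescence and BrdU incorporation, with a stated time of 48 h, tested at 25 uM; on this read-out lower numbers stand for a stronger effect and higher numbers for a weaker effect at the one concentration tested. Compound 1 `COc1cc(OC)c(C(=O)/C=C/c2ccccc2SC)c(OC)c1` gives 0.5%, compound 2 `COc1cccc(/C=C/C(=O)c2c(OC)cc(OC)cc2OC)c1` gives 0.6% and compound 3 `COc1cc(OC)c(C(=O)/C=C/c2ccc(Cl)cc2)c(OC)c1` gives 0%. Compound 1 stands second highest of the three, its steps to the others, a number 0.1 percentage points higher from compound 1 to compound 2 (within the scatter) and a number 0.5 percentage points lower from compound 1 to compound 3 (within the scatter), both within the scatter, as is a number 0.6 percentage points lower from compound 2 to compound 3 (within the scatter). Compound 4 `COc1cc(O)c(C(=O)/C=C/c2ccccc2SC)c(OC)c1` differs from compound 1 by hydrogen in place of methyl on an oxygen on an aromatic ring. Within the data shown here, none of the measured steps alters the core in this way; all three vary the aryl group on the chain, and each stays within the scatter. Without a comparable step, compound 4 is expected to show a shift of a number 3.5 percentage points higher from compound 1 to compound 4 (within the scatter), and its estimated value is 4%, ranging from 0% to 25%.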

Compound 4, a percentage reported as activity, at one concentration (the size of the read-out at that concentration, not a potency): 28%
Compound 4: the middle estimate sits 24 percentage points below what was measured; measured number above the stated range.
By their numbers in this assay, from the lowest: compounds 3, 1 and 2 (each within the scatter of the next); then compound 4.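

In this assay, hydrogen in place of methyl on an oxygen on an aromatic ring gives a number 27.5 percentage points higher from compound 1 to compound 4 (beyond the scatter). Among these compounds, this is the only step here that lies beyond the scatter, and it comes from the core, whereas the aryl changes on the chain among compound 1, compound 2 and compound 3 all stay within it. Nothing available bears on the reason for this weaker effect.

Going by these compounds, whether an amine or an ethoxy group at this place would behave like the hydroxy remains open. So does whether the same change would give a similar step with the 4-chlorophenyl of compound 3 or the 3-methoxyphenyl of compound 2.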